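The source may hold more compounds than are shown below. What is called first, only, known or untested is meant among the compounds shown, and "the series" means these compounds.

Measured compounds in the series:

Compound 1, `Cc1cc(Sc2ccncc2)c(S(C)(=O)=O)cc1C(=O)N=C(N)N`, in a functional assay for inhibition of sodium/hydrogen exchanger (Oryctolagus cuniculus) (a higher number here means a weaker inhibitor, a lower number a stronger inhibitor), gives 13 nM.
Compound 2, `Cc1cc(N2CCCCC2)c(S(C)(=O)=O)cc1C(=O)N=C(N)N`, in this assay gives 21 nM.

Within the data shown here, compound 2 carries the higher of the two numbers so far, but its only neighbour is compound 1, and the step of a 1.6-fold higher number from compound 1 to compound 2 (0.21 log units; within the scatter) sits inside the scatter; the two values cannot be told apart on these data.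

The next compound, compound 3, `Cc1cc(-n2ccnc2C)c(S(C)(=O)=O)cc1C(=O)N=C(N)N`, arises from compound 2 by the change (2-methyl-1H-imidazol-1-yl in place of piperidin-1-yl on an aromatic carbon). Among the measured compounds shown here, the one comparison that touches this position is the exchange from compound 1 to compound 2, where the piperidin-1-yl group replaced the (pyridin-4-yl)sulfanyl group and produced a 1.6-fold higher number from compound 1 to compound 2 (0.21 log units; within the scatter); that exchange suggests this position tolerates groups of rather different character without a shift beyond the scatter. On that single precedent the step to compound 3 is expected to be small, possibly a mild move toward a higher number but not one that can be called beyond the scatter with confidence.

Compound 3 is therefore estimated at 30 nM in this assay, within a range of 10 nM to 100 nM, corresponding to an expected step of a 1.4-fold higher number from compound 2 to compound 3 (0.15 log units; within the scatter).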

Compound 3, half-maximal inhibitory concentration: 29 nM
Beside the measured number, compound 3's estimate is 1.0-fold (0.01 log units) above it; low and high end bracket the measured number.
By their numbers in this assay, from the lowest: compounds 1, 2 and 3 (each within the scatter of the next, the first and the last beyond it).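

In this assay, the step of a 1.4-fold higher number from compound 2 to compound 3 (0.14 log units; within the scatter) shows that 2-methyl-1H-imidazol-1-yl, a five-membered aromatic ring, can take the place of piperidin-1-yl, a six-membered non-aromatic ring, ortho to the methylsulfonyl group without a change that can be told from the scatter. The series also now has its first step beyond the scatter, a 2.2-fold higher number from compound 1 to compound 3 (0.35 log units; beyond the scatter), although this separation is modest and compound 2 stays within the scatter of both other compounds, so the three groups tested here span only a narrow range of values at this position. No accompanying measurement bears on the origin of these steps.

The compounds shown do not separate the contribution of the methyl group on the imidazole from that of the ring itself, a question that the unsubstituted 1H-imidazol-1-yl group would address directly. They also leave open whether this position would keep its tolerance with an open-chain amine such as dimethylamino, a carboxylic acid, or a longer alkyl chain in place of these ring-bearing groups.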